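Working notes: one aryl swap in a sparse series

This account rests on a few compounds, and the source may have more. Where it says the series, first, only, none or still open, it means among the compounds named here.

Measured in a functional assay on HepG2 cells (Homo sapiens) for antiproliferative activity, read by MTT assay; a higher number here means a weaker inhibitor, a lower number a stronger inhibitor
compound 1 `CC1(C)CCc2cc(C(=O)/C=C/c3ccc(OCc4cn(-c5ccc(Br)cc5)nn4)cc3)c(O)cc2O1` gives "not active" (no number reported)
compound 2 `COc1ccc(-n2cc(COc3ccc(/C=C/C(=O)c4ccc5c(c4O)CCC(C)(C)O5)cc3)nn2)c([N+](=O)[O-])c1` gives 120000 nM

Within the data shown here, compound 2 holds the only number so far. The one further entry, compound 1, came without a number, so no ranking can be drawn. Compound 3 `Cc1ccc(-n2cc(COc3ccc(/C=C/C(=O)c4ccc5c(c4O)CCC(C)(C)O5)cc3)nn2)cc1Br` is still to be measured. The change is 3-bromo-4-methylphenyl in place of 4-methoxy-2-nitrophenyl on an aromatic nitrogen and it puts 3-bromo-4-methylphenyl in place of 4-methoxy-2-nitrophenyl on an aromatic nitrogen of the five-membered aromatic ring with 3 nitrogen.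

Among the measured compounds shown here, no two measured compounds differ in one place, so the data give no step size for this change. In this assay no step beyond the scatter is expected in either direction, and this is a default rather than a trend. Compound 1 holds bromine as well and gives "not active" (no number reported) in the same test, so a result without a number remains possible for compound 3.

The step expected is a 1.2-fold lower number from compound 2 to compound 3 (0.08 log units; within the scatter) by this estimate. For compound 3 the estimated value is 100000 nM with an expected range from 30000 nM to 300000 nM on this reading.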

Compound 3, half-maximal inhibitory concentration: 110000 nM
Beside the measured number, compound 3's estimate is 1.1-fold (0.04 log units) below it, within the range that was stated.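

In this assay, among these compounds, placing 3-bromo-4-methylphenyl instead of 4-methoxy-2-nitrophenyl on the aromatic nitrogen gives a 1.1-fold lower number from compound 2 to compound 3 (0.04 log units; within the scatter), the first step that can be read. At this position, then, a group with 3 hydrogen-bond acceptors gives way to one with 0, and a nitro and a methoxy group give way to a bromine and a methyl group, with no step beyond the scatter between the two aryl groups. No measured evidence bears on this result, and the data offer no explanation for it.

Steps involving compound 1 cannot be read, as it carries no number, so the only step available for this position remains one within the scatter. From the compounds shown here alone, whether this position can move the number beyond the scatter remains open, for example with a phenyl ring carrying an amine or a carboxylic acid, or with a longer alkyl chain on the same aromatic nitrogen.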